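A Methoxy Group Joins the Pyrimidine Ring

A few compounds are considered here, and "the series" means these few. Any claim that something is new, unique, unknown or untested is made for them only; others in the source may bear on it.

The measured compounds:
compound 1 `O=c1cc(CN(c2ccccc2)c2cccc(Cl)c2)c2ccc(F)c(F)c2[nH]1` gives 1500 nM
compound 2 `O=c1cc(CN(c2cccc(Cl)c2)c2ccccn2)c2ccc(F)c(F)c2[nH]1` gives 31 nM
compound 3 `O=c1cc(CN(c2cccc(Cl)c2)c2ccncn2)c2ccc(F)c(F)c2[nH]1` gives 14 nM

All three were tested in an assay on HEK293 cells for inhibition of Nitric oxide synthase, inducible (Homo sapiens), read by fluorescence; a higher number here means a weaker inhibitor, a lower number a stronger inhibitor. Compound 3 stands lowest of the three numbers, with compound 2 nearest and compound 1 furthest away. The steps between them are large when a whole ring is exchanged: a 48-fold lower number from compound 1 to compound 2 (1.68 log units; beyond the scatter) and a 110-fold lower number from compound 1 to compound 3 (2.03 log units; beyond the scatter), while the change between the two nitrogen-containing rings is smaller: a 2.2-fold lower number from compound 2 to compound 3 (0.35 log units; beyond the scatter).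

Compound 4 `COc1cc(N(Cc2cc(=O)[nH]c3c(F)c(F)ccc23)c2cccc(Cl)c2)ncn1` differs from compound 3 in one place: methoxy in place of hydrogen on an aromatic carbon. Going by the values given here, none of the measured steps involves adding a small group to a ring that is otherwise kept; each swaps one ring for another. The measured steps therefore give no direct guide, and the expectation is that the change from hydrogen to methoxy produces no step beyond the usual scatter, in either direction.

Compound 4 is therefore expected to give about 15 nM in this assay, within a range from 5 nM to 50 nM. This estimate means a step of a 1.1-fold higher number from compound 3 to compound 4 (0.03 log units; within the scatter), expected to stay within the scatter.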

Compound 4, half-maximal inhibitory concentration: 61 nM
For compound 4 the middle estimate is 4.1-fold (0.61 log units) below the measured one, and the stated range ends below it.
By their numbers in this assay, from the lowest: compound 3; then compounds 2 and 4 (each within the scatter of the next); then compound 1.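

Going by these compounds alone, compound 4 gives the first reading of a small group added to a ring that is otherwise kept: in this assay, the change from pyrimidin-4-yl to 6-methoxypyrimidin-4-yl brings a 4.4-fold higher number from compound 3 to compound 4 (0.64 log units; beyond the scatter) and so costs potency at this carbon next to the ring nitrogen. The cost is limited, as the comparison with the pyridin-2-yl compound shows a 2.0-fold higher number from compound 2 to compound 4 (0.29 log units; within the scatter) and stays within the scatter. Against the phenyl compound, the methoxy-bearing ring still keeps a clear gain, with a 25-fold lower number from compound 1 to compound 4 (1.39 log units; beyond the scatter) on the scale.

On these data alone, whether this loss belongs to methoxy itself or to any group on this carbon stays open, and a methyl, a fluorine, an amine or an ethoxy in the same place would separate those readings. As far as these compounds go, whether methoxy would have the same effect on the pyridin-2-yl ring is also open. Nothing available here accounts for the loss.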